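Replacing the propargyl group of compound 3

The compounds below may be only part of what the source reports. "The series", "measured", "known", "first", "only" and "open" are said of these compounds alone.

The series is followed in a functional assay on the whole organism with Rattus norvegicus as the target; a lower number here means that less compound is needed, a higher number that more compound is needed for the effect. Compound 1 `Nc1nc2ccc(C3CCCCC3)cc2s1` returns only a limit of the assay in this assay, > 10 mg/kg. Compound 2 `CCC(C)(C)c1ccc2nc(N)sc2c1` likewise returns only a limit of the assay, > 10 mg/kg. Among the measured compounds shown here, compound 3 `C#CCn1c(=N)sc2cc(OC(F)(F)F)ccc21` is the single member with a number in this assay, at 4 mg/kg. The two other entries sit at the limit of > 10 mg/kg in this assay, at which 2 of the 3 values shown sit, so compound 3 holds the only point from which a change can be gauged. For the measured compounds named here, no pair of measured compounds differs in a single place, and no measured step is therefore available.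

Compound 4 `CSCn1c(=N)sc2cc(OC(F)(F)F)ccc21` has not yet been measured. It differs from compound 3 in one place: methylsulfanyl in place of ethynyl on a saturated chain carbon bound to an aromatic nitrogen. Without a measured step to lean on, the working expectation is that this change costs some potency in this assay, with a step at the edge of the usual scatter or a little beyond it, towards a higher dose. The expected step is a 1.5-fold higher number from compound 3 to compound 4 (0.18 log units; within the scatter). Compound 4 is accordingly estimated to give 6 mg/kg in this assay, with a range from 2 mg/kg to 20 mg/kg. Given that two of the three measured compounds returned only a limit, a limit for compound 4 also remains a real possibility.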

Compound 4, dose for half-maximal effect: 3 mg/kg
Beside the measured number, compound 4's estimate is 2.0-fold (0.30 log units) above it; the range from low to high includes it.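

In this assay, the change from propargyl to (methylsulfanyl)methyl gives a 1.3-fold lower number from compound 3 to compound 4 (0.12 log units; within the scatter), so the two compounds cannot be told apart on this read-out. Until now, this position was known only with the propargyl group; compound 4 shows that a measurable dose does not depend on the triple bond of the ethynyl group, and that methylsulfanyl, which brings a sulfur atom and a hydrogen-bond acceptor by the count for this group, can stand on the saturated chain carbon bound to the aromatic nitrogen with no step beyond the scatter. Nothing at hand accounts for the close agreement between the two groups.

This single step rests on one pair sharing the rest of the structure, so it says nothing about whether the same exchange would read alike on a different core. Also open, as far as these compounds go, is how far the position stretches: a longer chain, an amine or a carboxylic acid on the same saturated chain carbon could show whether the dose in this assay stays in this range or moves clearly beyond the scatter.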